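Swapping Pyrimidin-5-yl for 1H-Indol-7-yl in a Cytotoxicity Test

This account rests on a few compounds, and the source may have more. Where it says the series, first, only, none or still open, it means among the compounds named here.

In a toxicity assay on MT4 cells (Homo sapiens) for cytotoxicity, read by MTT assay, with a stated time of 5 days (on this read-out lower numbers stand for higher toxicity in this test and higher numbers for lower toxicity in this test), compound 3 `Cc1cc(-c2cncnc2)cc(C)c1Nc1ccnc(Nc2ccc(C#N)cc2)n1` gives 6800 nM. This lies within the scatter of compound 1 `Cc1cnc(Nc2ccc(C#N)cc2)nc1Nc1c(F)cc(-c2cncc(C(F)(F)F)c2)cc1F` at 8200 nM, while compound 2 `Cc1cnc(Nc2ccc(C#N)cc2)nc1Nc1c(F)cc(-c2ccc(C#N)nc2)cc1F` gives 62000 nM. Compound 4 `Cc1cc(-c2cccc3cc[nH]c23)cc(C)c1Nc1ccnc(Nc2ccc(C#N)cc2)n1` differs from compound 3 in one place, 1H-indol-7-yl in place of pyrimidin-5-yl on an aromatic carbon.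

Going by the values given here, only one measured step offers any guidance: a 7.6-fold higher number from compound 1 to compound 2 (0.88 log units; beyond the scatter). It shows that exchanging one aromatic group for another can move the number in this assay beyond the scatter. That evidence is indirect, however, since the step involves other groups and a core different from that of compound 3. Among the compounds with values here, no compound with 1H-indol-7-yl has been measured, so neither the size nor the direction of the change is established. A small move towards a lower number is the tentative expectation, and no step beyond the scatter is anticipated. The expected step is a 1.4-fold lower number from compound 3 to compound 4 (0.13 log units; within the scatter). For compound 4 the estimated value is 5000 nM, with an expected range from 1800 nM to 14000 nM.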

Compound 4, half-maximal cytotoxic concentration: 1000 nM
Compound 4: middle estimate off by 5.0-fold (0.70 log units), on the high side; the measured number lies below the stated range.
By their numbers in this assay, from the lowest: compound 4; then compounds 3 and 1 (each within the scatter of the next); then compound 2.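

In this assay, the replacement on this aromatic carbon, meta to two methyl groups and para to a large group, gives a 6.8-fold lower number from compound 3 to compound 4 (0.83 log units; beyond the scatter), which shows that on this core the group at this position can shift the number beyond the scatter, here towards higher toxicity in this test. The change also has more than one part: a single six-membered ring with two hetero atoms and no hydrogen-bond donor gives way to a larger group of two aromatic rings that carries a hydrogen-bond donor and no acceptor. No measurement at hand bears on why the number falls.

The compounds shown leave open whether the added ring or the hydrogen-bond donor goes with the step. They also leave open where a plain phenyl group or a 1-methyl-1H-indol-7-yl group at this place would stand.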